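Ring nitrogen in the ethoxy-bearing arm: compound 4

The source may hold more compounds than are shown below. What is called first, only, known or untested is meant among the compounds shown, and "the series" means these compounds.

For the measured compounds named here, compound 3 `CCOc1ccc(-c2cc(C3CC(C)(C)OC(C)(C)C3)nn2-c2ccccc2OC)cc1` stands lowest of the three numbers so far in an assay on HEK293 cells for inhibition of Voltage-dependent N-type calcium channel subunit alpha-1B (Homo sapiens), read by patch clamp, using a membrane potential dye (a lower number here means a stronger inhibitor, a higher number a weaker inhibitor), at 61 nM. Compound 2 `COc1ccccc1-n1nc(C2CC(C)(C)OC(C)(C)C2)cc1-c1ccc(C#N)cc1` gives 130 nM and compound 1 `COc1ccccc1-n1nc(C2CC(C)(C)OC(C)(C)C2)cc1-c1ccnc(Cl)c1` gives 740 nM. The measured steps are a 5.7-fold lower number from compound 1 to compound 2 (0.76 log units; beyond the scatter), a 12-fold lower number from compound 1 to compound 3 (1.08 log units; beyond the scatter) and a 2.1-fold lower number from compound 2 to compound 3 (0.33 log units; beyond the scatter), all of them changes of the whole arm or of its terminal substituent. Compound 4 `CCOc1ccc(-c2cc(C3CC(C)(C)OC(C)(C)C3)nn2-c2ccccc2OC)cn1` differs from compound 3 by 6-ethoxypyridin-3-yl in place of 4-ethoxyphenyl on an aromatic carbon. Going by the values given here, no measured step isolates such an exchange of one ring carbon for a ring nitrogen: the only pair in which a six-membered ring with a hetero atom meets a carbon-only ring is a 12-fold lower number from compound 1 to compound 3 (1.08 log units; beyond the scatter), and there the substituent changes as well, so that step cannot be read as a guide. Among the compounds with values here, with no single-point precedent, the expectation for this assay is a step no larger than the scatter, in either direction. Compound 4 is therefore estimated at 90 nM, with a range from 35 nM to 250 nM. This estimate corresponds to an expected 1.5-fold higher number from compound 3 to compound 4 (0.17 log units; within the scatter).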

Compound 4, half-maximal inhibitory concentration: 200 nM
Beside the measured number, compound 4's estimate is 2.2-fold (0.35 log units) below it; the range from low to high includes it.
By their numbers in this assay, from the lowest: compound 3; then compounds 2 and 4 (each within the scatter of the next); then compound 1.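

In this assay, for the compounds shown here, exchanging one ring carbon of the 4-ethoxyphenyl arm for a ring nitrogen while keeping the ethoxy group gives a 3.3-fold higher number from compound 3 to compound 4 (0.52 log units; beyond the scatter), the first step to isolate this exchange, and it shows that this single change at this position is enough to shift the number beyond the scatter. The ethoxy arm's edge over the 4-cyanophenyl arm does not survive the exchange, with a 1.5-fold higher number from compound 2 to compound 4 (0.19 log units; within the scatter), while the 6-ethoxypyridin-3-yl arm keeps a clear lead over the 2-chloropyridin-4-yl arm, with a 3.7-fold lower number from compound 1 to compound 4 (0.57 log units; beyond the scatter). Nothing available bears on the reason for the step.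

Still open, going by these compounds, is whether the same ring nitrogen has a similar effect in the 4-cyanophenyl arm. Also open, on these data alone, is how a longer chain such as propoxy, or an amine such as dimethylamino, would behave in place of ethoxy on the 6-ethoxypyridin-3-yl arm.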